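The source may hold more compounds than are shown below. What is called first, only, known or untested is meant among the compounds shown, and "the series" means these compounds.

Measured so far:
compound 1 `C[C@@H](NC(=O)Nc1ccccc1C(F)(F)F)c1ccccc1` — 95%
compound 2 `C[C@@H](NC(=O)Nc1ccccc1F)c1ccccc1` — 95%

In an ADME assay on the whole organism with Oryza sativa as the target, tested at 1 uM (a lower number here means a stronger effect, a higher number a weaker effect of the compound at the concentration tested), compound 1 gives 95% and compound 2 gives 95%. The single step between them, no change at the digits printed from compound 1 to compound 2 (within the scatter), came with fluoro in place of trifluoromethyl on an aromatic carbon, so compound 2 stands level with compound 1 at the digits shown, inside the scatter of this kind of measurement.

Compound 3 `C[C@@H](NC(=O)Nc1ccccc1Cl)c1ccccc1` is not yet measured. It differs from compound 2 as follows: chloro in place of fluoro on an aromatic carbon. The exchange sits at the same aromatic carbon that was altered between compound 1 and compound 2.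

Among the measured compounds shown here, only one measured step bears on this change, no change at the digits printed from compound 1 to compound 2 (within the scatter), where an exchange of the group on that aromatic carbon left this assay unchanged within the scatter. For the measured compounds named here, nothing among the measured compounds points to a different outcome for chloro. The step of a number 2 percentage points lower from compound 2 to compound 3 (within the scatter) is expected to fall within the scatter, in no definite direction. For compound 3 the estimate in this assay is 93%, with a range from 80% to 100%.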

Compound 3, a percentage reported as activity, at one concentration (the size of the read-out at that concentration, not a potency): 103%
The estimate for compound 3 lay 10 percentage points below the measured number; the measured number lies above the stated range.
By their numbers in this assay, from the lowest: compounds 1, 2 and 3 (each within the scatter of the next).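

Changing the group on this aromatic carbon to chloro adds a third substituent to the comparison in this assay: the read-out shows a number 8 percentage points higher from compound 2 to compound 3 (within the scatter) and a number 8 percentage points higher from compound 1 to compound 3 (within the scatter), so chloro does not separate from either fluoro or trifluoromethyl. Fluoro, chloro and trifluoromethyl therefore form a set of three exchanges at one position, and every step among them lies within the scatter, which gives no rank order for these three groups and no measurable sensitivity to the exchange among them in this assay. Nothing available explains this flat picture, and no cause can be assigned to it.

Still open, from the compounds shown here alone, is whether a group of a different kind on this aromatic carbon, such as an amine, a methoxy group or a carboxylic acid, would move the read-out beyond the scatter. Also open, going by these compounds, is whether changes elsewhere on the shared core would do so, since all three compounds differ at this one carbon alone and each read-out comes from a single concentration rather than a potency.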